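This account rests on a few compounds, and the source may have more. Where it says the series, first, only, none or still open, it means among the compounds named here.

Three compounds share one core here: compound 1 `CC(C)c1noc(N2CCC(Oc3cc(N4CCc5cc(C6CCCCC6=O)ccc54)ncn3)CC2)n1`, compound 2 `CC(C)c1noc(N2CCC(Oc3cc(N4CCc5cc(N6CCCS6(=O)=O)ccc54)ncn3)CC2)n1` and the still unmeasured compound 3 `CC(C)c1noc(N2CCC(Oc3cc(N4CCc5cc(N6CCOCC6=O)ccc54)ncn3)CC2)n1`. In an ADME assay on microsomes from liver (Homo sapiens) for metabolic stability, read by LC-MS, using NADPH, with a stated time of 30 min, tested at 1 uM (on this read-out higher numbers stand for fast clearance and lower numbers for slow clearance), compound 1 gives 78 mL.min-1.g-1 and compound 2 gives 18 mL.min-1.g-1, so compound 2 holds the lower of the two numbers. The change now in question is a group of 7 heavy atoms (4 carbon, 1 nitrogen, 2 oxygen; one six-membered non-aromatic ring with 2 hetero atoms) in place of a group of 7 heavy atoms (3 carbon, 1 nitrogen, 2 oxygen, 1 sulfur; one five-membered non-aromatic ring with 2 hetero atoms), on an aromatic carbon. The five-membered non-aromatic ring group of compound 2 gives way to 3-oxomorpholin-4-yl, on an aromatic carbon of a six-membered aromatic ring of carbon only, meta to a fused ring and para to a fused ring. Among the compounds with values here, one measured step bears on this, made on the same aromatic carbon: a 4.3-fold lower number from compound 1 to compound 2 (0.64 log units; beyond the scatter), which lies beyond the scatter. In that step, a six-membered ring of carbon only left. The entering group of compound 3 also has a six-membered ring, but one with hetero atoms, as the group in compound 2 has. A single step is a thin guide, so only a small rise in this assay is expected, not one beyond the scatter. The estimated step is a 1.4-fold higher number from compound 2 to compound 3 (0.14 log units; within the scatter). Compound 3 is expected at 25 mL.min-1.g-1, with an estimated range of 11 mL.min-1.g-1 to 55 mL.min-1.g-1.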

Compound 3, intrinsic clearance in microsomes: 27 mL.min-1.g-1
For compound 3 the middle estimate is 1.1-fold (0.03 log units) below the measured one; the measured number falls inside the stated range.
By their numbers in this assay, from the lowest: compounds 2 and 3 (each within the scatter of the next); then compound 1.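

In this assay, the move from the five-membered non-aromatic ring group with its two hetero atoms to 3-oxomorpholin-4-yl on this aromatic carbon gives a 1.5-fold higher number from compound 2 to compound 3 (0.18 log units; within the scatter) and so leaves the number within the usual scatter, although ring size and ring atoms both change and the sulfur is gone. The same entering group in place of 2-oxocyclohexyl gives a 2.9-fold lower number from compound 1 to compound 3 (0.46 log units; beyond the scatter) at this position, so a second group with a hetero-atom ring now stands apart from the carbon-only ring, and none of the three compounds goes against this. Nothing shown here offers an explanation for either step.

Ring size and ring atoms change together across these three compounds, so what the compounds shown leave open is which of the two matters, and a 2-oxopyrrolidin-1-yl group, with a five-membered ring and no sulfur, would separate them. Also open, on these data alone, is how this position responds to groups of another kind, such as an open-chain amide, a piperazine with its basic amine, or a carboxylic acid.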